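The source may report more compounds than this note shows. Statements on the series, on what has been measured and on what is new or still open speak of the compounds shown alone.

Measured so far in a toxicity assay on THP-1 cells (Homo sapiens) for inhibition; a higher number here means that more compound is tolerated, a lower number that less compound is tolerated:
compound 1, `COc1ccc(-c2cnc(NC(=O)c3cccnc3)n2C)cc1`: > 100000 nM
compound 2, `Cn1c(-c2ccc(F)cc2)cnc1NC(=O)c1ccc(F)cc1`: > 100000 nM
compound 3, `COc1ccc2c(c1)nc(NC(=O)c1ccc(F)cc1)n2C`: > 100000 nM

In this assay compound 1 gives > 100000 nM, which is a limit of the assay and not a number. Compound 2 gives > 100000 nM in this assay, again a limit. Compound 3 gives > 100000 nM in this assay, also a limit. Going by the values given here, compound 2 thus stands at the limit of > 100000 nM in this assay, at which 3 of the 3 values shown sit; no measured value separates it from compound 1 or compound 3, and no pair of measured compounds differs in only one place, so no measured step in this assay can be read off.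

The next compound is compound 4, `Cn1c(-c2ccccc2)cnc1NC(=O)c1ccc(F)cc1`. Relative to compound 2 the change is hydrogen in place of fluoro on an aromatic carbon. The three values shown give no reason to expect a step beyond the scatter in either direction; the step from compound 2 to compound 4 is expected to be a number no higher from compound 2 to compound 4 (the limit leaves the size open). Compound 4 is therefore expected to give about 100000 nM in this assay, within 50000 nM to 200000 nM, and most likely to be reported again only as a limit.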

Compound 4, half-maximal cytotoxic concentration: > 100000 nM
Compound 4 was reported as a limit; the forecaster's own chance of this, stated with the estimate: 85%; the middle value lies on the limit itself.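

In this assay compound 4 gives > 100000 nM, a limit of the assay and not a number. Compound 2 also stands at a limit, so no step can be read for 4-fluorophenyl to phenyl. The compounds shown leave open what concentration, if any, would reach half-maximal cytotoxicity for either compound.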